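Isopropoxy in place of benzylamino: cytotoxicity notes

The source may hold more compounds than are shown below. What is called first, only, known or untested is meant among the compounds shown, and "the series" means these compounds.

Two compounds on the shared core frame this step: compound 1 (`CSc1nc(N)nc2c1ncn2[C@@H]1O[C@H](CO)[C@@H](O)[C@@]1(C)O`) and compound 2 (`C[C@@]1(O)[C@H](O)[C@@H](CO)O[C@H]1n1cnc2c(NCc3ccccc3)nc(N)nc21`). In an ADME assay on Huh-7 cells (Homo sapiens) for cytotoxicity (on this read-out lower numbers stand for higher toxicity in this test and higher numbers for lower toxicity in this test), compound 1 gives > 100000 nM, which is a limit of the assay and not a number. For compound 2 the entry in this assay is "not determined" (no result reported), so compound 2 has no place on the scale and offers no starting number for the step.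

The next compound to be read is compound 3 (`CC(C)Oc1nc(N)nc2c1ncn2[C@@H]1O[C@H](CO)[C@@H](O)[C@@]1(C)O`). The structural change is isopropoxy in place of benzylamino on an aromatic carbon, with isopropoxy in place of benzylamino on an aromatic carbon.

Among the measured compounds shown here, the series holds no measured step, so nothing gives a size or direction for this change. No shift beyond the usual scatter is expected in this assay. This expectation rests only on compound 1, whose > 100000 nM is a limit. Compound 3 may therefore also be reported only as a limit. For compound 3 the expected value is 90000 nM, with an estimated range from 40000 nM to 100000 nM.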

Compound 3, half-maximal cytotoxic concentration: > 100000 nM
Compound 3 was reported as a limit; the forecaster's own chance of this, stated with the estimate: 75%; middle value at least 1.1-fold (0.04 log units) away from the limit.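

In this assay compound 3 gives > 100000 nM, which is a limit of the assay. No new step can be read, since compound 1 and compound 3 both stand at a limit: the limit of > 100000 nM in this assay, at which 2 of the 3 values shown sit.

The compounds shown leave open whether any group on this aromatic carbon of the shared core brings the read-out within the measurable range.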